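This account rests on a few compounds, and the source may have more. Where it says the series, first, only, none or still open, it means among the compounds named here.

Compound 1 `COc1ccc(C#Cc2ccc(C(=O)N3CCC[C@@H](CO)C3)cc2)c(F)c1` belongs to a set of three compounds measured in a functional assay on TREX cells for negative allosteric modulation of metabotropic glutamate receptor 3 (Rattus norvegicus), read by calcium flux, with a stated time of 2.5 min; on this read-out lower numbers stand for stronger inhibition and higher numbers for weaker inhibition. In this assay compound 1 gives only the limit > 10000 nM and no number. Compound 3 `COc1ccc(C#Cc2ccc(C(=O)N3CCC[C@@H](CO)C3)cc2)c(F)c1F` likewise gives only the limit > 10000 nM in this assay. The step that the two limits leave unreadable from compound 1 to compound 3 therefore cannot be read. Compound 2 `COc1ccc(C#Cc2ccc(C(=O)N3CC[C@@H](O)C3)cc2)cc1` gives 10200 nM in this assay, a weak value.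

Compound 4 `COc1ccc(C#Cc2ccc(C(=O)N3CCC[C@@H](CO)C3)cc2)cn1` differs from compound 1 by 6-methoxypyridin-3-yl in place of 2-fluoro-4-methoxyphenyl on a triple-bonded carbon. Among the measured compounds shown here, no measured step touches this change, and the limit of > 10000 nM in this assay, at which 2 of the 3 values shown sit, marks where most of the values sit. Compound 4 is therefore expected to show a step that the limit leaves unreadable from compound 1 to compound 4, staying weak in this assay. For compound 4 the estimate is 15000 nM, with a range from 5000 nM to 50000 nM.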

Compound 4, half-maximal inhibitory concentration: > 10000 nM
Compound 4 gave a limit, no number; the forecaster's own chance of this, stated with the estimate: 70%; the middle value lies beyond the limit too.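

Among the compounds shown here, compound 4 gives only the limit > 10000 nM in this assay, and compound 1 also gives only a limit, so no step between them can be read. The compounds shown leave open whether 6-methoxypyridin-3-yl in place of 2-fluoro-4-methoxyphenyl changes inhibition at all.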